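Pyridine-ring substituent changes in a potassium channel inhibitor series

The compounds below may be only part of what the source reports. "The series", "measured", "known", "first", "only" and "open" are said of these compounds alone.

Of the compounds shown here, three on a shared core have been measured in an assay on T-REx-293 cells for inhibition of potassium channel subfamily T member 1 (Homo sapiens), read by patch clamp; a lower number here means a stronger inhibitor, a higher number a weaker inhibitor. Compound 1 `Cc1ccnc(-c2noc([C@H](C)NC(=O)c3cc(C(F)(F)F)nn3C)n2)c1` gives 4470 nM. Compound 2 `Cc1cc(-c2noc([C@H](C)NC(=O)c3cc(C(F)(F)F)nn3C)n2)ccn1` gives 165 nM, and compound 3 `C[C@H](NC(=O)c1cc(C(F)(F)F)nn1C)c1nc(-c2ccnc(C3CC3)c2)no1` gives 16 nM, the lowest of the three numbers, with a 10-fold lower number from compound 2 to compound 3 (1.01 log units; beyond the scatter) and a 280-fold lower number from compound 1 to compound 3 (2.45 log units; beyond the scatter) both beyond the scatter. Compound 4 `CNc1cc(-c2noc([C@H](C)NC(=O)c3cc(C(F)(F)F)nn3C)n2)ccn1` is not yet measured; it differs from compound 3 by methylamino in place of cyclopropyl on an aromatic carbon. The step bearing most directly on this is a 10-fold lower number from compound 2 to compound 3 (1.01 log units; beyond the scatter), a large gain from a single group swap at the same place; a 27-fold lower number from compound 1 to compound 2 (1.43 log units; beyond the scatter) shows the arrangement on that ring matters as well. Methylamino has no precedent here, so direction is uncertain; since a 10-fold lower number from compound 2 to compound 3 (1.01 log units; beyond the scatter) came with cyclopropyl, removing it is expected to give a 3.8-fold higher number from compound 3 to compound 4 (0.57 log units; beyond the scatter). Compound 4 is therefore estimated at 60 nM, ranging from 10 nM to 400 nM.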

Compound 4, half-maximal inhibitory concentration: 195 nM
Compound 4: the middle estimate sits 3.3-fold (0.51 log units) below what was measured, and the stated range covers the measured number.
By their numbers in this assay, from the lowest: compound 3; then compounds 2 and 4 (each within the scatter of the next); then compound 1.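

Methylamino in place of cyclopropyl, next to the ring nitrogen, gives a 12-fold higher number from compound 3 to compound 4 (1.09 log units; beyond the scatter) and so does not keep the gain seen with cyclopropyl, while methylamino in place of methyl gives a 1.2-fold higher number from compound 2 to compound 4 (0.07 log units; within the scatter) and the two groups cannot be told apart at this place. The 2-(methylamino)pyridin-4-yl group still gives a 23-fold lower number from compound 1 to compound 4 (1.36 log units; beyond the scatter) against the 4-methylpyridin-2-yl arrangement, so the advantage of that arrangement holds with a second substituent. Nothing on hand explains the difference between cyclopropyl and methylamino. From the compounds shown here alone, whether cyclobutyl or isopropyl matches cyclopropyl here remains open, as does whether dimethylamino tracks methylamino.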